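Removing the Benzyl Methyl in a Hydroxamate Series

The source may report more compounds than this note shows. Statements on the series, on what has been measured and on what is new or still open speak of the compounds shown alone.

Compound 2 `Cc1ccc(CN2C(=O)N(c3ccc(Cl)cc3)C(=O)C2CCC(=O)Nc2ccc(C(=O)NO)cc2)cc1` carries a methyl on the benzyl ring of the shared core. In an assay on isolated protein for inhibition of histone deacetylase 9 (Homo sapiens), read by fluorescence, with stated times of 5 min and 60 min (a higher number here means a weaker inhibitor, a lower number a stronger inhibitor), compound 2 gives only a limit, > 100000 nM, so among the numbers shown it stands at the weaker end, without a number of its own. Its bromo counterpart, compound 1 `O=C(CCC1C(=O)N(c2ccc(Cl)cc2)C(=O)N1Cc1ccc(Br)cc1)Nc1ccc(C(=O)NO)cc1`, gives 9100 nM in this assay. Among the compounds with values here, the single measured step, an at least 10-fold higher number from compound 1 to compound 2 (1.04 log units; beyond the scatter), was large, and it rests on (the limit of > 100000 nM in this assay, at which 1 of the 2 values shown sits), so its true size is open. Compound 3 `O=C(CCC1C(=O)N(c2ccc(Cl)cc2)C(=O)N1Cc1ccccc1)Nc1ccc(C(=O)NO)cc1` differs from compound 2 by hydrogen in place of methyl on an aromatic carbon. Within the data shown here, no measured step shows a methyl removed, and the bromo-to-methyl step points only to a large change in one direction. Compound 3 is therefore expected to fall somewhere between the two numbers seen, a step of an at least 2.8-fold lower number from compound 2 to compound 3 (0.45 log units; beyond the scatter), with an estimate of 35000 nM and a range from 9000 nM to 150000 nM.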

Compound 3, half-maximal inhibitory concentration: 15200 nM
The estimate for compound 3 lay 2.3-fold (0.36 log units) above the measured number; the measured number falls inside the stated range.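

In this assay, hydrogen in place of bromo gives a 1.7-fold higher number from compound 1 to compound 3 (0.22 log units; within the scatter), so these two groups are not separated at this position on the benzyl ring. The methyl alone stands apart: hydrogen in place of methyl gives an at least 6.5-fold lower number from compound 2 to compound 3 (0.81 log units; beyond the scatter), which places the large change seen earlier with the methyl itself and not with the loss of the bromo. Going by these compounds, how large this step really is stays open, because compound 2 gives only a limit and not a number: the limit of > 100000 nM in this assay, at which 1 of the 3 values shown sits.

On these data alone, whether an ethyl, a methoxy or a chloro at this place would read like hydrogen and bromo or like methyl remains open. With only three groups shown, it also remains open whether the methyl is a lone exception or the first sign of a wider trend.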